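The compounds below may be only part of what the source reports. "The series", "measured", "known", "first", "only" and "open" are said of these compounds alone.

Measured compounds:
- Compound 1, `O=C(NC1CCN(Cc2ccccc2)CC1)c1coc2ccccc2c1=O`: 63.8%
- Compound 2, `COc1ccc2occ(C(=O)NC3CCN(Cc4ccccc4)CC3)c(=O)c2c1`: 7.5%
- Compound 3, `O=C(NCCC1CCN(Cc2ccccc2)CC1)c1coc2ccccc2c1=O`: 68.6%

In an assay on isolated protein for inhibition of Amine oxidase [flavin-containing] A (Homo sapiens), read by fluorescence and Amplex Red, with stated times of 15 min and 20 min, tested at 100 uM (on this read-out lower numbers stand for less inhibition and higher numbers for more inhibition at the one concentration tested (going by the name of the read-out)), compound 1 gives 63.8%. Compound 2 carries one change against compound 1, (methoxy in place of hydrogen on an aromatic carbon), and in this assay compound 2 gives 7.5%. For the measured compounds named here, the step of a number 56.3 percentage points lower from compound 1 to compound 2 (beyond the scatter) is the only change in the set for which a counted step is available, and it is a large one.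

Compound 3 is built on a different core; how the core of compound 3 differs from that of compound 1 is not broken down here. In this assay compound 3 gives 68.6%, a number that lies within the scatter of the value of compound 1, so the two cores cannot be told apart on this read-out.

Compound 4, `COc1ccc2c(=O)c(C(=O)NCCC3CCN(Cc4ccccc4)CC3)coc2c1`, has not yet been measured. It stands to compound 3 as compound 2 stands to compound 1: methoxy in place of hydrogen on an aromatic carbon. The place of the change is the same in its printed words for both pairs, so this is the same change made on the second core. Going by the values given here, with only one earlier instance of the change, and with the two cores giving numbers within the scatter of each other in this assay, the expectation for compound 4 is a step of about the same size as the one from compound 1 to compound 2: the estimated step is a number 55.6 percentage points lower from compound 3 to compound 4 (beyond the scatter), resting on the value of compound 3, 68.6%, and on a number 56.3 percentage points lower from compound 1 to compound 2 (beyond the scatter). Compound 4 is therefore expected to give about 13% in this assay, with a likely range from 2% to 35%.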

Compound 4, a percentage reported as inhibition, at one concentration (the size of the read-out at that concentration, not a potency): 32.4%
Estimate against measurement, compound 4: 19.4 percentage points below; the measured number falls inside the stated range.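

In this assay, methoxy in place of hydrogen on an aromatic carbon lowers the number on the second core as well, giving a number 36.2 percentage points lower from compound 3 to compound 4 (beyond the scatter). The direction of the step therefore holds in both pairs, but its size does not carry over unchanged from one core to the other: the same change on two cores in this assay, a number 56.3 percentage points lower (beyond the scatter) from compound 1 to compound 2 and a number 36.2 percentage points lower (beyond the scatter) from compound 3 to compound 4, 20.1 percentage points apart, beyond the scatter of two such steps Two pairs are too few to show a general rule for this series, and they do not show what sets the size of the step on each core, nor whether the same direction would appear on any further core; as the read-out is a percentage at one concentration, they also say nothing about potency.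

The compounds shown leave open whether a fluorine, a chlorine, a hydroxy group or an ethoxy group in the same place would lower the number as methoxy does, and whether the size of the step would again differ between the two cores. They also leave open how methoxy would behave on another carbon of the six-membered aromatic ring, and whether a longer chain between the amide and the piperidine would shift the step further.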